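The source may hold more compounds than are shown below. What is called first, only, known or untested is meant among the compounds shown, and "the series" means these compounds.

Compound 1 `COc1nc(-c2cccc(Cl)c2)ccc1[C@@H](c1ccccc1)[C@@](O)(CCN(C)C)c1cccc2ccccc12` gives > 50 ug/mL in a toxicity assay on Vero cells (Chlorocebus sabaeus) for cytotoxicity (a higher number here means that more compound is tolerated, a lower number that less compound is tolerated), which is a limit of the assay rather than a number.
Compound 2 `COc1nc(-c2ccsc2)ccc1[C@@H](c1ccccc1)[C@@](O)(CCN(C)C)c1cccc2ccccc12` gives 24.4 ug/mL in this assay.
Compound 3 `COc1nc(-c2ccncc2)ccc1[C@@H](c1ccccc1)[C@@](O)(CCN(C)C)c1cccc2ccccc12` gives > 50 ug/mL in this assay, again a limit rather than a number.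

Compound 1 therefore stands at the top of what was measured: its value is only a limit, and the limit of > 50 ug/mL in this assay, at which 2 of the 3 values shown sit, shows that compound 3 sits at the same limit, while compound 2 alone gives a number. The unmeasured compound 4 `COc1nc(-c2cccc(F)c2)ccc1[C@@H](c1ccccc1)[C@@](O)(CCN(C)C)c1cccc2ccccc12` differs from compound 1 by a single swap: fluoro in place of chloro on an aromatic carbon.

The measured steps all exchange the whole ring attached to the shared core. They run an at least 2.0-fold lower number from compound 1 to compound 2 (0.31 log units; beyond the scatter), an at least 2.0-fold higher number from compound 2 to compound 3 (0.31 log units; beyond the scatter) and a step that the two limits leave unreadable from compound 1 to compound 3. None of them exchanges one halogen for another on a ring that is otherwise kept, so they bear on the step to compound 4 only loosely; they show that the core with a six-membered carbon ring carrying a chloro, or with pyridin-4-yl, is tolerated to the limit.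

Given that compound 1 gives > 50 ug/mL, compound 4 is expected to show a number no higher from compound 1 to compound 4 (the limit leaves the size open), that is no step beyond the scatter. Compound 4 is estimated at 50 ug/mL, with a range from 25 ug/mL to 100 ug/mL, most likely reported again as a limit.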

Compound 4, half-maximal cytotoxic concentration: > 50 ug/mL
Compound 4 gave a limit, no number (the forecaster's own chance of this, stated with the estimate: 65%); the middle value sits exactly at the limit.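

The 3-fluorophenyl ring now joins 3-chlorophenyl and pyridin-4-yl among the groups on the shared core that reach the assay's limit in this assay, so the tolerance of compound 1 does not depend on the chloro specifically. Going by these compounds alone, compound 2, with thiophen-3-yl, remains the only compound with a true number, and changing that ring to 3-fluorophenyl gives an at least 2.0-fold higher number from compound 2 to compound 4 (0.31 log units; beyond the scatter). The steps among compound 1, compound 3 and compound 4 cannot be read, since both ends of each are limits, and most of the set now sits at one ceiling: the limit of > 50 ug/mL in this assay, at which 3 of the 4 values shown sit.

From the compounds shown here alone, neither compound 1 nor compound 4 has a real number, so the true size of the swap from chloro to fluoro stays open, and it could be nil or substantial. Also open, going by these compounds, is whether another group at this place on the ring, such as trifluoromethyl, an amine or a carboxylic acid, would bring the tolerated amount down to a readable number, as the thiophen-3-yl ring of compound 2 does.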